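Aryl exchange on the amide-type nitrogen of compound 3

The source may report more compounds than this note shows. Statements on the series, on what has been measured and on what is new or still open speak of the compounds shown alone.

In a functional assay on the whole organism for inhibition, with Rattus norvegicus as the target, read by paw edema, with stated times of 30 min and 5 h, at a dose of 0.28 mmol/kg by the oral route (a lower number here means less inhibition, a higher number more inhibition at the dose given (going by the name of the read-out)), three members of the series have been measured. Compound 1 `COc1ccc(-n2nc(C(N)=O)nc2-c2cc(OC)c(OC)c(OC)c2)cc1` gives 64%. Compound 2 `CCNC(=O)c1nc(-c2cc(OC)c(OC)c(OC)c2)n(-c2ccc(OC)cc2)n1` gives 52%. Compound 3 `COc1ccc(NC(=O)c2nc(-c3cc(OC)c(OC)c(OC)c3)n(-c3ccc(OC)cc3)n2)cc1` gives 51% and stands lowest of the three numbers; its gap to compound 2 lies within the scatter, while its gap to compound 1 lies beyond it. The measured steps read a number 12 percentage points lower from compound 1 to compound 2 (beyond the scatter) and a number 13 percentage points lower from compound 1 to compound 3 (beyond the scatter), both modest, and a number 1 percentage points lower from compound 2 to compound 3 (within the scatter), within the scatter.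

Compound 4 `COc1ccc(-n2nc(C(=O)Nc3ccccc3C)nc2-c2cc(OC)c(OC)c(OC)c2)cc1` differs from compound 3 in one place: 2-methylphenyl in place of 4-methoxyphenyl on an amide-type nitrogen. Among the compounds with values here, the steps that bear on this are those altering the same amide-type nitrogen. Putting 4-methoxyphenyl in place of hydrogen gave a number 13 percentage points lower from compound 1 to compound 3 (beyond the scatter); putting 4-methoxyphenyl in place of ethyl gave a number 1 percentage points lower from compound 2 to compound 3 (within the scatter). Within the data shown here, no measured step exchanges one aryl group on this nitrogen for another, so the trade of 4-methoxyphenyl for 2-methylphenyl has no direct precedent here. Because a number 1 percentage points lower from compound 2 to compound 3 (within the scatter) falls within the scatter, the step expected for compound 4 is a number 1 percentage points lower from compound 3 to compound 4 (within the scatter), none beyond the scatter. Compound 4 is therefore estimated in this assay at 50%, with a range from 38% to 62%.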

Compound 4, a percentage reported as inhibition, in the whole organism at one dose (the size of the read-out at that dose, not a potency): 47%
Estimate against measurement, compound 4: 3 percentage points above, within the range that was stated.
By their numbers in this assay, from the lowest: compounds 4, 3 and 2 (each within the scatter of the next); then compound 1.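

In this assay, the exchange of one aryl group for another on the amide-type nitrogen, 2-methylphenyl in place of 4-methoxyphenyl, reads a number 4 percentage points lower from compound 3 to compound 4 (within the scatter) and so leaves the number unmoved beyond the usual spread, even with the hydrogen-bond acceptor of 4-methoxyphenyl gone. Set against the ethyl group, 2-methylphenyl gives a number 5 percentage points lower from compound 2 to compound 4 (within the scatter) and so does not separate from the alkyl amide, while set against hydrogen it gives a number 17 percentage points lower from compound 1 to compound 4 (beyond the scatter) as a modest step in the same direction as the ethyl and 4-methoxyphenyl steps. At this position the listed numbers thus divide only between the unsubstituted amide of compound 1 and the three substituted amides, with no order among compounds 2, 3 and 4, and nothing on hand gives a reason for these steps.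

Open, on these data alone, is whether a longer chain in place of ethyl, or an aryl group carrying an amine or a carboxylic acid, would stand apart from compounds 2, 3 and 4 on this nitrogen. Also open, as far as these compounds go, is whether these close readings at a single oral dose would hold at other doses.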